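Two Close Values and a Missing Methyl

This account rests on a few compounds, and the source may have more. Where it says the series, first, only, none or still open, it means among the compounds named here.

Measured so far in a functional assay on thoracic aorta (Rattus norvegicus, strain Wistar), with a stated time of 15 min; on this read-out lower numbers stand for an effect already at smaller amounts and higher numbers for an effect only at larger amounts of compound:
- compound 1 `CC(NC(=O)NS(=O)(=O)c1ccc(Cl)cc1)c1cc(Br)ccc1OCc1ccccc1` gives 57500 nM
- compound 2 `CCOc1ccc(Br)cc1C(C)NC(=O)N(C)S(=O)(=O)c1ccc(Cl)cc1` gives 55700 nM

Compound 2 stands within the usual scatter of compound 1, so neither ranks ahead. Compound 3 `CCOc1ccc(Br)cc1C(C)NC(=O)NS(=O)(=O)c1ccc(Cl)cc1` differs from compound 2 in one place (hydrogen in place of methyl on an amide-type nitrogen), with hydrogen in place of methyl on an amide-type nitrogen. Among the measured compounds shown here, no measured pair shows this change alone. Compound 1 also has hydrogen on that nitrogen and gives (57500 nM), though it differs elsewhere too. The expected step is therefore small, with no move beyond the scatter (a 1.4-fold lower number from compound 2 to compound 3 (0.14 log units; within the scatter)). The estimated value for compound 3 is 40000 nM (expected range 12000 nM to 110000 nM).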

Compound 3, half-maximal effective concentration: 171000 nM
Beside the measured number, compound 3's estimate is 4.3-fold (0.63 log units) below it; the measured number lies above the stated range.
By their numbers in this assay, from the lowest: compounds 2 and 1 (each within the scatter of the next); then compound 3.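

In this assay, the methyl on the amide-type nitrogen whose other neighbours are the carbonyl carbon and sulfonyl sulfur proves to matter: hydrogen in its place gives a 3.1-fold higher number from compound 2 to compound 3 (0.49 log units; beyond the scatter) and so moves the number beyond the scatter. A second site counts too, since methyl in place of phenyl on the saturated chain carbon bound to an oxygen on an aromatic ring gives a 3.0-fold higher number from compound 1 to compound 3 (0.47 log units; beyond the scatter) as well. Nothing available explains either step.

Going by these compounds, whether an ethyl or a longer chain on that nitrogen would shift the number further stays open. So does whether the two changes add up when combined.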